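From 2-bromobenzyl to 3-bromobenzyl on the sulfur

This account rests on a few compounds, and the source may have more. Where it says the series, first, only, none or still open, it means among the compounds named here.

In a functional assay on HepG2 cells (Homo sapiens) for antiproliferative activity, read by MTT assay, with a stated time of 24 h (on this read-out lower numbers stand for stronger inhibition and higher numbers for weaker inhibition), compound 1 (`Sc1nnc(-c2ccc3c(c2)OCCO3)n1-c1ccccc1`) gives 60000 nM on this read-out. Compound 2 (`Clc1ccccc1CSc1nnc(-c2ccc3c(c2)OCCO3)n1-c1ccccc1`) gives 970 nM and compound 3 (`Brc1ccccc1CSc1nnc(-c2ccc3c(c2)OCCO3)n1-c1ccccc1`) gives 4730 nM as the second highest of the three numbers. Compound 4 (`Brc1cccc(CSc2nnc(-c3ccc4c(c3)OCCO4)n2-c2ccccc2)c1`) has 3-bromophenyl in place of 2-bromophenyl on a saturated chain carbon bound to a sulfur. Two large steps came with putting a substituted benzyl on the sulfur: a 62-fold lower number from compound 1 to compound 2 (1.79 log units; beyond the scatter) and a 13-fold lower number from compound 1 to compound 3 (1.10 log units; beyond the scatter) for the two halogenated compounds. Among the compounds with values here, neither resembles the present change, and no measured pair shows bromo at two different places. The closest guide is the modest 4.9-fold higher number from compound 2 to compound 3 (0.69 log units; beyond the scatter) for a single halogen exchange with the benzyl group kept. A step of no more than that modest size is therefore expected in this assay and its direction cannot be told from these data. The estimated step is a 1.2-fold lower number from compound 3 to compound 4 (0.07 log units; within the scatter) with only a slight lean. For compound 4 the estimated value is 4000 nM within an expected range of 1300 nM to 13000 nM on this read-out.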

Compound 4, half-maximal inhibitory concentration: 5210 nM
Beside the measured number, compound 4's estimate is 1.3-fold (0.11 log units) below it; the range from low to high includes it.
By their numbers in this assay, from the lowest: compound 2; then compounds 3 and 4 (each within the scatter of the next); then compound 1.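

In this assay, the 2-bromobenzyl and 3-bromobenzyl compounds read alike, with a 1.1-fold higher number from compound 3 to compound 4 (0.04 log units; within the scatter), so at this place the two bromo arrangements cannot be told apart. The large step that came with a substituted benzyl on the sulfur also holds for the 3-bromobenzyl group, at a 12-fold lower number from compound 1 to compound 4 (1.06 log units; beyond the scatter). The 2-chlorobenzyl compound remains separated from this new bromo compound as well, by a 5.4-fold higher number from compound 2 to compound 4 (0.73 log units; beyond the scatter), so among the compounds shown the difference goes with the chloro compound and does not depend on where the bromine sits.

No measurement shown accounts for this lack of difference between the two bromo compounds. From the compounds shown here alone, whether chloro would behave like bromo at the other place, and how an amine or a carboxylic acid in place of the bromine would read, stays open.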